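This account rests on a few compounds, and the source may have more. Where it says the series, first, only, none or still open, it means among the compounds named here.

Compound 1 `Cc1nn(C)c2c1C(c1cccc(Cl)c1)=NCCN2` gives 0.63 mg/kg in a functional assay on the whole organism for positive allosteric modulation, with Rattus norvegicus as the target (on this read-out higher numbers stand for an effect only at larger amounts of compound and lower numbers for an effect already at smaller amounts), and stands level with compound 2 `Cc1nn(C)c2c1C(c1cccc(Cl)c1)=NCCN2C`, which gives 0.63 mg/kg in this assay; the step of no change at the digits printed from compound 1 to compound 2 (within the scatter) lies within the scatter. Compound 3 `Cc1cccc(C2=NCCNc3c2c(C)nn3C)c1` differs from compound 1 by methyl in place of chloro on an aromatic carbon. Among the measured compounds shown here, the only measured step concerns a nitrogen of the shared core, not this aromatic carbon, so it offers no direct guide; it shows only that one small change left the read-out unmoved. Compound 3 is therefore expected to give about 0.63 mg/kg in this assay, within 0.3 mg/kg to 1.6 mg/kg. The expected step of no change at the digits printed from compound 1 to compound 3 (within the scatter) would then stay within the scatter.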

Compound 3, minimum effective dose: 2.5 mg/kg
For compound 3 the middle estimate is 4.0-fold (0.60 log units) below the measured one, outside the stated range (above it).
By their numbers in this assay, from the lowest: compounds 1 and 2 (each within the scatter of the next); then compound 3.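

In this assay, the aromatic carbon meta to a large group proves sensitive to a single exchange of one heavy atom: methyl in place of chloro gives a 4.0-fold higher number from compound 1 to compound 3 (0.60 log units; beyond the scatter). The earlier step at the core nitrogen, by contrast, was no change at the digits printed from compound 1 to compound 2 (within the scatter), so the two places on the molecule do not respond alike to these changes. No available evidence bears on the reason for this difference. The compounds shown leave open how other groups on this aromatic carbon, such as fluoro, methoxy or an amine, would compare with chloro and methyl.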